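Solubility notes on a chloro to (trifluoromethyl)sulfanyl swap

The source may report more compounds than this note shows. Statements on the series, on what has been measured and on what is new or still open speak of the compounds shown alone.

Measured in a physicochemical assay for solubility, using the shake flask method, in simulated intestinal fluid, measured as kinetic solubility, with a stated time of 2 h, at 25 degrees C, at pH 6.5; on this read-out lower numbers stand for lower solubility and higher numbers for higher solubility:
compound 1 `Cc1noc(-c2nc(C)c3c(c2N)C(=O)N(CC2CCNCC2)C3=O)n1`: 160000 nM
compound 2 `Cc1noc(-c2nc(C)c3c(c2N)C(=O)N(Cc2ccc(Cl)cc2)C3=O)n1`: < 5000 nM
compound 3 `Cc1noc(-c2nc(C)c3c(c2N)C(=O)N(Cc2ccccc2F)C3=O)n1`: < 5000 nM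

Compound 2 sits at a limit of this assay, not at a number; (the limit of < 5000 nM in this assay, at which 2 of the 3 values shown sit). Compound 3 likewise sits at a limit. Compound 1 alone carries a number. The two readable steps, an at least 32-fold lower number from compound 1 to compound 2 (1.50 log units; beyond the scatter) and an at least 32-fold lower number from compound 1 to compound 3 (1.50 log units; beyond the scatter), each swap piperidin-4-yl for an aryl group and each end at the limit. a step that the two limits leave unreadable from compound 2 to compound 3.

Compound 4 `Cc1noc(-c2nc(C)c3c(c2N)C(=O)N(Cc2ccc(SC(F)(F)F)cc2)C3=O)n1` differs from compound 2 by (trifluoromethyl)sulfanyl in place of chloro on an aromatic carbon. Among the measured compounds shown here, no measured step alters a substituent on the aryl ring, so none bears directly on this change; both aryl compounds shown sit at the limit. Compound 4 is therefore expected to stay at or under the limit, the step that the limit leaves unreadable from compound 2 to compound 4 being unreadable against a limit. The estimate for compound 4 is 2000 nM, range 400 nM to 5000 nM.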

Compound 4, solubility: < 5000 nM
Compound 4 was reported as a limit (the forecaster's own chance of this, stated with the estimate: 85%); the middle value is on the limit's open side.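

Among the compounds shown here, compound 2 and compound 4 both sit at a limit in this assay, and no step between them can be read: the limit of < 5000 nM in this assay, at which 3 of the 4 values shown sit.

From the compounds shown here alone, whether (trifluoromethyl)sulfanyl in place of chloro changes the read-out at all stays open, as does where either compound lies under that limit.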